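A few compounds are considered here, and "the series" means these few. Any claim that something is new, unique, unknown or untested is made for them only; others in the source may bear on it.

Measured so far:

- compound 1, `C=CC1=C(C(=O)Nc2ccccc2)C(c2ccc(Cl)c(Cl)c2)OC1` — in a functional assay on QGY7701 cells (Homo sapiens) for cytotoxicity, read by MTT assay, with a stated time of 24 h (on this read-out higher numbers stand for weaker inhibition and lower numbers for stronger inhibition), compound 1 gives > 100000 nM, a limit of the assay rather than a number.
- compound 2, `C=CC1=C(C(=O)NCc2ccc(Cl)cc2)C(c2ccc(OC)cc2)OC1` — in this assay compound 2 gives > 100000 nM, again a limit, not a number.
- compound 3, `C=CC1=C(C(=O)NCc2ccccc2F)C(c2ccc(F)cc2)OC1` — in this assay compound 3 gives 51400 nM.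

Compound 2 stands at the limit, where two of the three values sit (the limit of > 100000 nM in this assay, at which 2 of the 3 values shown sit); only compound 3 returns a number, and that number is itself weak. Among the compounds with values here, no step between measured compounds differs in a single place, so no measured step size is available for this series.

Compound 4, `C=CC1=C(C(=O)Nc2ccc(C)cc2)C(c2ccc(OC)cc2)OC1`, is the next compound to be measured. It differs from compound 2 in one place (4-methylphenyl in place of 4-chlorobenzyl on an amide-type nitrogen); the shared core and the 4-methoxyphenyl group on the ring are kept.

With every measured value weak or at the limit, no change beyond the scatter is expected in this assay. The step of a number no higher from compound 2 to compound 4 (the limit leaves the size open) is expected to be no larger than the scatter. Compound 4 is expected at 100000 nM, within 40000 nM to 300000 nM, with a fair chance that only a limit is returned.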

Compound 4, half-maximal inhibitory concentration: > 100000 nM
Compound 4: no number, only a limit (the forecaster's own chance of this, stated with the estimate: 65%); the middle value lies on the limit itself.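

Within the data shown here, compound 2 and compound 4 both return only limits, so no step between them can be read: the limit of > 100000 nM in this assay, at which 3 of the 4 values shown sit.

The compounds shown leave open whether 4-methylphenyl in place of 4-chlorobenzyl on an amide-type nitrogen changes the cytotoxicity read-out at all.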